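The source may report more compounds than this note shows. Statements on the series, on what has been measured and on what is new or still open speak of the compounds shown alone.

In a functional assay on MOLT-4 cells (Homo sapiens) for inhibition (a lower number here means a stronger inhibitor, a higher number a weaker inhibitor), two compounds that share one core give only a limit. Compound 1, `O=C1/C(=C/c2ccc(Cl)cc2)Cc2ccccc21`, returns a limit of > 500000 nM in this assay. Compound 2, `O=C1/C(=C/c2ccc(Br)cc2)Cc2ccccc21`, likewise returns a limit of > 500000 nM in this assay. The change between them is bromo in place of chloro on an aromatic carbon, and it gives a step that the two limits leave unreadable from compound 1 to compound 2; no size can be read for it because two of the three values sit at the limit of > 500000 nM in this assay, at which 2 of the 3 values shown sit. Compound 3, `O=C1CCCCC/C1=C\c1ccc(Cl)cc1`, carries a different core; the difference between the two cores is not broken down here. In this assay, going by the values given here, compound 3 gives 52600 nM, the only number among the three values.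

Compound 4, `O=C1CCCCC/C1=C\c1ccc(Br)cc1`, has not yet been measured. It differs from compound 3 by bromo in place of chloro on an aromatic carbon. Among the compounds with values here, this is the same kind of change as the one from compound 1 to compound 2, though the surroundings differ: in compound 3 the halogen sits para to a group of 9 heavy atoms, in compound 1 para to a large group. Within the data shown here, the earlier step left no readable size, so the expectation rests on compound 3 alone, whose 52600 nM in this assay is the one number available. Since the entering bromo, like the leaving chloro, counts as one heavy atom with no donor or acceptor, the expected step is a 1.2-fold lower number from compound 3 to compound 4 (0.07 log units; within the scatter), a small one. Compound 4 is therefore estimated at 45000 nM in this assay, with a range from 18000 nM to 120000 nM.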

Compound 4, half-maximal inhibitory concentration: 49400 nM
The estimate for compound 4 lay 1.1-fold (0.04 log units) below the measured number; low and high end bracket the measured number.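

On the core of compound 3, bromo in place of chloro on an aromatic carbon gives a 1.1-fold lower number from compound 3 to compound 4 (0.03 log units; within the scatter) in this assay, so on this core the chloro and bromo compounds cannot be told apart. The same change on the core of compound 1 cannot be read, because both compounds on that core give only a limit, so there is no size to set beside the new step: the limit of > 500000 nM in this assay, at which 2 of the 4 values shown sit. The series therefore gives one readable result for this change, on one core, and it does not show whether the change behaves the same way on the core of compound 1.

The compounds shown carry only chloro or bromo on the aromatic ring, so what a methoxy group, a nitrile, an amine or a carboxylic acid in that place would do in this assay remains open. Also open, from the compounds shown here alone, is whether any such group would bring the core of compound 1 to a measured number rather than a limit, which would give the change a second readable step for comparison.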